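This account rests on a few compounds, and the source may have more. Where it says the series, first, only, none or still open, it means among the compounds named here.

Compounds measured in a functional assay on HCC78 cells (Homo sapiens) for antiproliferative activity, read by MTT assay, with a stated time of 48 h; on this read-out lower numbers stand for stronger inhibition and higher numbers for weaker inhibition:
compound 1 `Cc1ccc(CNC(=O)c2cccc(C(C)Oc3ccnc(Nc4cnn(C)c4)c3)c2)cc1` with 8900 nM
compound 2 `Cc1ccc(CNC(=O)c2cccc(C(C)Oc3ccnc(NN4CCOCC4)c3)c2)cc1` with 68300 nM
compound 3 `Cc1ccc(CNC(=O)c2cccc(C(C)Oc3ccnc(NN4CCN(C)CC4)c3)c2)cc1` with 26200 nM

On these three numbers compound 3 stands second highest. Its nearest neighbour is compound 2, with a 2.6-fold lower number from compound 2 to compound 3 (0.42 log units; beyond the scatter) separating them, and its furthest is compound 1, with a 2.9-fold higher number from compound 1 to compound 3 (0.47 log units; beyond the scatter) between them. The shared core is kept throughout; the three compounds differ only in the group carried on the nitrogen attached to the aromatic ring.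

Compound 4 `Cc1ccc(CNC(=O)c2cccc(C(C)Oc3ccnc(Nc4nc5ccccc5[nH]4)c3)c2)cc1` has not yet been measured in this assay. It differs from compound 3 in that (1H-benzimidazol-2-yl in place of 4-methylpiperazin-1-yl on a nitrogen on an aromatic ring). The change removes the six-membered non-aromatic ring with two hetero atoms and brings in a fused aromatic system with one hydrogen-bond donor.

Among the compounds with values here, two measured steps bear on this. Going from the aromatic 1-methyl-1H-pyrazol-4-yl of compound 1 to the saturated rings gave a 7.7-fold higher number from compound 1 to compound 2 (0.89 log units; beyond the scatter) and a 2.9-fold higher number from compound 1 to compound 3 (0.47 log units; beyond the scatter); the saturated rings sit at the weaker end. Compound 4 returns an aromatic group to this position, so a lower number than compound 3 is expected in this assay, of a size comparable to the step that separates compound 3 from compound 1, with real uncertainty because no fused aromatic group has been tested here.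

The estimate for compound 4 is therefore 7000 nM, with a range from 1500 nM to 30000 nM, which would mean an expected step of a 3.7-fold lower number from compound 3 to compound 4 (0.57 log units; beyond the scatter).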

Compound 4, half-maximal inhibitory concentration: > 100000 nM
Compound 4 ended at the assay's limit; the forecaster's own chance of this, stated with the estimate: 5%; middle value at least 14-fold (1.15 log units) away from the limit.
By their numbers in this assay, from the lowest: compound 1; then compound 3; then compound 2. At a limit, above all of these: compound 4.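

In this assay, the result for compound 4 is a limit of the assay and not a number: the limit of > 100000 nM in this assay, at which 1 of the 4 values shown sits. An aromatic group on this nitrogen is therefore not enough to preserve activity, since the change to 1H-benzimidazol-2-yl gives an at least 11-fold higher number from compound 1 to compound 4 (1.05 log units; beyond the scatter), a large step between two aromatic groups, and also an at least 3.8-fold higher number from compound 3 to compound 4 (0.58 log units; beyond the scatter), which places this fused group behind the saturated 4-methylpiperazin-1-yl. Against morpholin-4-yl the same group gives an at least 1.4-fold higher number from compound 2 to compound 4 (0.16 log units; that floor lies within the scatter), and with that floor inside the scatter, this pair cannot be put in order.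

The compounds shown leave open whether the loss follows the added six-membered aromatic ring of carbon only, the hydrogen-bond donor of 1H-benzimidazol-2-yl, or the larger group as a whole. As far as these compounds go, a simple phenyl or a 1-methyl-1H-benzimidazol-2-yl at the same place would separate these readings, and the true distance of compound 4 from the other compounds remains unknown.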